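A few compounds are considered here, and "the series" means these few. Any claim that something is new, unique, unknown or untested is made for them only; others in the source may bear on it.

Among the measured compounds shown here, in a functional assay on HeLa cells (Homo sapiens) for inhibition, read by MTT assay, with a stated time of 72 h (a higher number here means a weaker inhibitor, a lower number a stronger inhibitor), compound 2 (`COc1cc(NC(C)CCCNC(=O)Nc2cccc(C(F)(F)F)c2)c2ncccc2c1`) gives 14000 nM, the lower of the two numbers measured so far, while compound 1 (`COc1cc(NC(C)CCCNC(=O)NNC(=O)Nc2ccc(Cl)cc2)c2ncccc2c1`) gives 120000 nM. Compound 3 (`COc1cc(NC(C)CCCNC(=O)NNC(=O)Nc2ccc(O)cc2)c2ncccc2c1`) has ((4-hydroxyphenyl)carbamoyl)amino in place of 3-(trifluoromethyl)phenyl on an amide-type nitrogen. For the measured compounds named here, only one measured step bears on this change: an 8.6-fold lower number from compound 1 to compound 2 (0.93 log units; beyond the scatter), a modest step beyond the scatter. That step replaces ((4-chlorophenyl)carbamoyl)amino with 3-(trifluoromethyl)phenyl at the same place, so the change to compound 3 runs in roughly the opposite direction. Going by the values given here, no measured step shows what a hydroxy group in place of the chloro group does, which leaves the estimate uncertain. In this assay the expected result is a higher number, a 5.0-fold higher number from compound 2 to compound 3 (0.70 log units; beyond the scatter), somewhat smaller than the measured step. The estimated value for compound 3 is 70000 nM, with an expected range of 20000 nM to 200000 nM.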

Compound 3, half-maximal inhibitory concentration: 85000 nM
Estimate against measurement, compound 3: 1.2-fold (0.08 log units) below, and the stated range covers the measured number.
By their numbers in this assay, from the lowest: compound 2; then compounds 3 and 1 (each within the scatter of the next).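

In this assay, among the compounds shown here, hydroxy in place of chloro on an aromatic carbon gives a 1.4-fold lower number from compound 1 to compound 3 (0.15 log units; within the scatter), the first measured swap of this substituent, and it leaves the two numbers within the scatter of each other. The larger change on the amide-type nitrogen gives a 6.1-fold higher number from compound 2 to compound 3 (0.78 log units; beyond the scatter), so the gap to compound 2 that was first seen with the chloro compound also appears with the hydroxy compound. Nothing available explains either result.

The compounds shown do not separate the contribution of the ((4-hydroxyphenyl)carbamoyl)amino linkage from that of the aromatic substituent, since compound 2 differs from compound 3 in both. As far as these compounds go, it remains open how an amine or a carboxylic acid in place of the hydroxy group would read, or a 4-chlorophenyl group carried directly on the amide-type nitrogen.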